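Swapping a chlorophenyl for a catechol on a cyclohexanone dienone

The compounds below may be only part of what the source reports. "The series", "measured", "known", "first", "only" and "open" are said of these compounds alone.

Compound 1 `COc1cccc(/C=C2\CCC/C(=C\c3cc(Cl)cc(Cl)c3)C2=O)c1OC` and compound 2 `COc1ccc(/C=C2\CCC/C(=C\c3ccc(Cl)cc3)C2=O)cc1OC` share a core and differ in their aryl groups. In a functional assay on MCF7 cells (Homo sapiens) for cytotoxicity, read by MTT assay, with a stated time of 72 h (on this read-out lower numbers stand for stronger inhibition and higher numbers for weaker inhibition), compound 1 gives 4300 nM, and compound 2 gives 6300 nM, which falls within the usual scatter of compound 1. Compound 3 `COc1ccc(/C=C2\CCC/C(=C\c3ccc(O)c(O)c3)C2=O)cc1OC` has not been measured; it differs from compound 2 by 3,4-dihydroxyphenyl in place of 4-chlorophenyl on a double-bonded chain carbon bound to a double-bonded ring carbon. Among the compounds with values here, with no measured step of this kind available, the author expects no change beyond the scatter, so the step from compound 2 to compound 3 is estimated at a 1.3-fold lower number from compound 2 to compound 3 (0.10 log units; within the scatter). Compound 3 is expected to give 5000 nM, between 1500 nM and 15000 nM.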

Compound 3, half-maximal inhibitory concentration: 14400 nM
The estimate for compound 3 lay 2.9-fold (0.46 log units) below the measured number, and the stated range covers the measured number.
By their numbers in this assay, from the lowest: compounds 1 and 2 (each within the scatter of the next); then compound 3.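

In this assay the change to 3,4-dihydroxyphenyl in place of 4-chlorophenyl on a double-bonded chain carbon bound to a double-bonded ring carbon gives a 2.3-fold higher number from compound 2 to compound 3 (0.36 log units; beyond the scatter) and so goes beyond the scatter. Within the data shown here, this is the first single-place step at this position, and it shows that the number responds to the aryl group there. No measurement given here explains the rise.

The compounds shown leave open whether the higher number goes with the two entering hydroxyl groups or with the loss of the chlorine. A 4-hydroxyphenyl or a 3,4-dimethoxyphenyl at this place would help separate the two.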